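The compounds below may be only part of what the source reports. "The series", "measured", "known", "first", "only" and "open" are said of these compounds alone.

Compound 1 `O=C(CN1CCN(S(=O)(=O)c2ccc(F)cc2)CC1)Nc1ccc(F)cc1` gives 13800 nM in an in vitro assay on HEK ts201 cells for negative allosteric modulation of Neuronal acetylcholine receptor; alpha4/beta2 (Homo sapiens), read by fluorescence and calcium flux, with a stated time of 1.5 s; on this read-out higher numbers stand for weaker inhibition and lower numbers for stronger inhibition. Compound 2 `O=C(CN1CCN(S(=O)(=O)c2ccccc2F)CC1)Nc1ccc(F)cc1` carries 2-fluorophenyl in place of 4-fluorophenyl on a sulfonyl sulfur, and in this assay compound 2 gives 8000 nM, a step of a 1.7-fold lower number from compound 1 to compound 2 (0.24 log units; within the scatter). Compound 3 `O=C(CN1CCN(S(=O)(=O)c2ccc(F)cc2)CC1)Oc1ccccc1-c1ccccc1` has a different core from compound 1, and the difference between the two cores is not broken down here; in this assay compound 3 gives 12200 nM. Compound 4 `O=C(CN1CCN(S(=O)(=O)c2ccccc2F)CC1)Oc1ccccc1-c1ccccc1` is the not yet measured partner of compound 3, related to it by 2-fluorophenyl in place of 4-fluorophenyl on a sulfonyl sulfur, the same change seen from compound 1 to compound 2. Since that earlier step was a 1.7-fold lower number from compound 1 to compound 2 (0.24 log units; within the scatter), compound 4 is expected to show a step of a 1.6-fold lower number from compound 3 to compound 4 (0.21 log units; within the scatter) in this assay. On this basis compound 4 is estimated to give about 7500 nM in this assay, with a plausible range from 3000 nM to 18000 nM.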

Compound 4, half-maximal inhibitory concentration: 20900 nM
Beside the measured number, compound 4's estimate is 2.8-fold (0.45 log units) below it; measured number outside the range, above it.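

In this assay, 2-fluorophenyl in place of 4-fluorophenyl on a sulfonyl sulfur gave a 1.7-fold higher number from compound 3 to compound 4 (0.23 log units; within the scatter), so the direction of the earlier step did not carry over to the core of compound 3. Each step alone lies within the scatter, yet the two steps differ by more than that scatter: the same change on two cores in this assay, a 1.7-fold lower number (0.24 log units; within the scatter) from compound 1 to compound 2 and a 1.7-fold higher number (0.23 log units; within the scatter) from compound 3 to compound 4, 3.0-fold (0.47 log units) apart, beyond the scatter of two such steps. This shows that the step on the core of compound 1 did not predict the step on the core of compound 3, but two pairs do not show why, or how the change would read on any further core.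

The compounds shown leave open how an unsubstituted phenyl, a chlorophenyl or a methoxyphenyl on the sulfonyl sulfur would read on these two cores. From the compounds shown here alone, a pyridine ring in that place also remains open.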